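Swapping Propyl for Thiophen-3-yl at the Carbonyl Carbon

The source may hold more compounds than are shown below. What is called first, only, known or untested is meant among the compounds shown, and "the series" means these compounds.

Compound 2 `CCCC(=O)NC(=S)N1CCc2c(OCCCCCOc3ccc(Cl)cc3)cccc21` carries a propyl group on a carbonyl carbon. In an ADME assay on Huh-7 cells (Homo sapiens) for cytotoxicity (on this read-out lower numbers stand for higher toxicity in this test and higher numbers for lower toxicity in this test), compound 2 gives > 50000 nM, and this is a limit of the assay rather than a measured number. Compound 1 `O=C(NC(=S)N1CCc2c(OCCCCCOc3ccc(Cl)cc3)cccc21)c1ccc(Cl)cc1` differs from it only in having a 4-chlorophenyl group at that carbon, and in this assay compound 1 gives 21700 nM. Going by these compounds, the step of an at least 2.3-fold higher number from compound 1 to compound 2 (0.36 log units; beyond the scatter) thus went toward lower toxicity, but its full size stays open because compound 2 sits at the limit of > 50000 nM in this assay, at which 1 of the 2 values shown sits.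

Compound 3 `O=C(NC(=S)N1CCc2c(OCCCCCOc3ccc(Cl)cc3)cccc21)c1ccsc1` puts an aromatic ring back at the same carbon: thiophen-3-yl in place of propyl on a carbonyl carbon. Among the compounds with values here, the one measured step bearing on this, from an aromatic ring to propyl, raised the number in this assay; the reverse kind of change, from propyl to an aromatic ring, is therefore expected to lower it again, though a thiophen-3-yl ring is not a 4-chlorophenyl ring and the size of the effect is uncertain. The step of an at least 1.4-fold lower number from compound 2 to compound 3 (0.15 log units; that floor lies within the scatter) is expected to be modest and downward. Compound 3 is estimated to come in around 35000 nM, most likely between 15000 nM and 70000 nM.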

Compound 3, half-maximal cytotoxic concentration: > 50000 nM
Compound 3 ended at the assay's limit; the forecaster's own chance of this, stated with the estimate: 40%; middle value at least 1.4-fold (0.15 log units) away from the limit.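

In this assay compound 3 gives > 50000 nM, which is a limit of the assay and not a measured number. With an at least 2.3-fold higher number from compound 1 to compound 3 (0.36 log units; beyond the scatter), the change of thiophen-3-yl for 4-chlorophenyl shows that an aromatic ring on this carbonyl carbon does not by itself bring the number down, so among the three compounds shown the lower number goes with the 4-chlorophenyl group of compound 1, not with aromatic rings in general. The step between compound 2 and compound 3 cannot be read, and propyl and thiophen-3-yl cannot be ranked against each other, because both compounds stand at the same limit: the limit of > 50000 nM in this assay, at which 2 of the 3 values shown sit.

Going by these compounds, how far the true values of compound 2 and compound 3 lie from that limit stays open, so any difference between these two groups remains hidden. Also open, on these data alone, is which part of the 4-chlorophenyl group goes with the lower number, a question that a plain phenyl ring on the same carbon could address, and what a carboxylic acid or an amine at the end of a longer chain would do there.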